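A few compounds are considered here, and "the series" means these few. Any claim that something is new, unique, unknown or untested is made for them only; others in the source may bear on it.

Working notes on the series. Within the data shown here, compound 1 `CCOC(=O)C1=Cc2ccccc2OC1(OCc1cn(CC(=O)Nc2cccc(Cl)c2)nn1)C(F)(F)F` is the only compound with a number in a functional assay on MCF7 cells (Homo sapiens) for inhibition, read by MTT assay, with a stated time of 24 h (a higher number here means a weaker inhibitor, a lower number a stronger inhibitor), where compound 1 gives 11600 nM. Compound 2 `CCOC(=O)C1=Cc2ccccc2OC1(OCc1cc(-c2ccc([N+](=O)[O-])cc2)no1)C(F)(F)F` in this assay gives > 150000 nM, which is a limit of the assay and not a number (the limit of > 150000 nM in this assay, at which 1 of the 2 values shown sits). Compound 3 `CCOC(=O)C1=Cc2ccccc2OC1(OCc1cn(-c2ccc([N+](=O)[O-])cc2)nn1)C(F)(F)F` has not yet been measured in this assay; it differs from compound 1 by 4-nitrophenyl in place of ((3-chlorophenyl)carbamoyl)methyl on an aromatic nitrogen. Among the measured compounds shown here, no step between two measured compounds is available, so the size of this change has to be estimated. Compound 2, which also carries 4-nitrophenyl, returns in this assay only > 150000 nM, a limit. On this the expectation for compound 3 rests: the step of a 5.2-fold higher number from compound 1 to compound 3 (0.71 log units; beyond the scatter) is expected to run towards a weaker inhibitor and to exceed the scatter. Compound 3 is therefore expected near 60000 nM, between 15000 nM and 150000 nM, with a real chance that only a limit is returned.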

Compound 3, half-maximal inhibitory concentration: > 150000 nM
Compound 3 was reported as a limit (the forecaster's own chance of this, stated with the estimate: 45%); middle value at least 2.5-fold (0.39 log units) from the limit.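

In this assay, among these compounds, the first step that can be read at this position, on an aromatic nitrogen of a five-membered aromatic ring with 3 nitrogen, is an at least 12-fold higher number from compound 1 to compound 3 (1.11 log units; beyond the scatter). With the rest of the molecule unchanged, the substituent on this nitrogen alone therefore decides whether a measurable number is returned at all. The value of compound 3 is a limit of the assay and not a number, so the step gives only a minimum size, and compound 3 now sits at that ceiling: the limit of > 150000 nM in this assay, at which 2 of the 3 values shown sit.

The compounds shown leave open which part of ((3-chlorophenyl)carbamoyl)methyl carries the difference: the chlorine, the amide hydrogen or the chain. An unsubstituted phenyl or 4-aminophenyl on that nitrogen, or a (phenylcarbamoyl)methyl group without the chlorine, would begin to separate these.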